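The source may report more compounds than this note shows. Statements on the series, on what has been measured and on what is new or still open speak of the compounds shown alone.

In a functional assay (aorta) with Rattus norvegicus as the target (on this read-out higher numbers stand for an effect only at larger amounts of compound and lower numbers for an effect already at smaller amounts), compound 2 `COc1ccc(-c2nc(/N=C(\N)[N+]3(C)CCCCC3)sc2-c2ccc(OC)cc2)cc1` gives 21 uM, the highest of the three measured numbers. Compound 3 `COc1ccc(-c2nc(CNC(=O)CSc3ccccc3)sc2-c2ccc(OC)cc2)cc1` gives 4.2 uM, and compound 1 `CNC(=N)Nc1nc(-c2ccc(OC)cc2)c(-c2ccc(OC)cc2)s1` gives 1.2 uM. Compound 4 `COc1ccc(-c2nc(CNC(=O)CSC)sc2-c2ccc(OC)cc2)cc1` is still unmeasured, and its difference from compound 2 is this: a group of 7 heavy atoms (4 carbon, 1 nitrogen, 1 oxygen, 1 sulfur; no ring) in place of a group of 10 heavy atoms (7 carbon, 3 nitrogen; one six-membered non-aromatic ring with 1 hetero atom), on an aromatic carbon. For the measured compounds named here, the only measured step that touches this change is an 18-fold higher number from compound 1 to compound 2 (1.24 log units; beyond the scatter). That step is large and beyond the scatter, and it came with the arrival of the same ring-bearing group that now leaves. Going by the values given here, no measured step covers the incoming chain on its own. A clearly lower number is therefore expected in this assay, close to compound 3 at 4.2 uM. For compound 4 the estimated value is 5 uM, within an expected range from 1.5 uM to 15 uM. The expected step is a 4.2-fold lower number from compound 2 to compound 4 (0.62 log units; beyond the scatter).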

Compound 4, concentration for half-maximal effect: 6 uM
Beside the measured number, compound 4's estimate is 1.2-fold (0.08 log units) below it; low and high end bracket the measured number.
By their numbers in this assay, from the lowest: compound 1; then compounds 3 and 4 (each within the scatter of the next); then compound 2.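

In this assay, replacing the ring-bearing group that carries a net charge of +1 with an uncharged chain on this aromatic carbon gives a 3.5-fold lower number from compound 2 to compound 4 (0.54 log units; beyond the scatter), so the charged group is not needed for a number in this range. The group on the chain's sulfur makes no clear difference here, with methyl in place of phenyl giving a 1.4-fold higher number from compound 3 to compound 4 (0.15 log units; within the scatter). The ring-free group with three nitrogens still gives the lower number, as a 5.0-fold higher number from compound 1 to compound 4 (0.70 log units; beyond the scatter) shows.

Nothing available explains these differences. The compounds shown leave open whether a benzyl group on that sulfur, or a longer chain between the amide nitrogen and the aromatic carbon, would keep the number in this range.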